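Phenoxy Replaced by a Halogenated Benzyl: Solubility Outlook

This account rests on a few compounds, and the source may have more. Where it says the series, first, only, none or still open, it means among the compounds named here.

Compound 1, `c1ccc(Oc2ccc3c(NCCCNCc4ccco4)ccnc3c2)cc1`, stands at the top of the two solubility numbers gathered so far. In a physicochemical assay for solubility, with a stated time of 18 h, at pH 7.4 (on this read-out higher numbers stand for higher solubility and lower numbers for lower solubility), compound 1 gives 14500 nM. Compound 2, `COc1cccc(CNCCCNc2ccnc3cc(CCC(C)C)ccc23)c1O`, differs from it in several places at once, and in this assay compound 2 gives 4200 nM; the gap between these two values lies beyond the usual scatter, so compound 1 is the more soluble of the pair.

Compound 3, `Fc1ccc(Cc2ccc3c(NCCCNCc4ccco4)ccnc3c2)c(Cl)c1`, has not yet been measured. It differs from compound 1 in one place: 2-chloro-4-fluorobenzyl in place of phenoxy on an aromatic carbon. For the measured compounds named here, no measured pair shows this exact change, so no measured step can be leaned on. The step that this estimate means, a 2.9-fold lower number from compound 1 to compound 3 (0.46 log units; beyond the scatter), is expected to point downward, beyond the scatter but not dramatically. In this assay compound 3 is estimated at 5000 nM, within a range from 1500 nM to 15000 nM.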

Compound 3, solubility: 4200 nM
Estimate against measurement, compound 3: 1.2-fold (0.08 log units) above; the measured number falls inside the stated range.
By their numbers in this assay, from the lowest: compounds 2 and 3 (each within the scatter of the next); then compound 1.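

At this aromatic carbon, with the rest of compound 1 unchanged, 2-chloro-4-fluorobenzyl in place of phenoxy gives a 3.5-fold lower number from compound 1 to compound 3 (0.54 log units; beyond the scatter) in this assay. For the compounds shown here, this is the only step in the set that isolates one change, so it shows that the read-out does respond to what sits at this position, although the step is modest. No measurement here accounts for the step, so it cannot be assigned to the lost oxygen, the chlorine, the fluorine or the extra carbon.

As far as these compounds go, it remains open how an unsubstituted benzyl group, which would separate the halogens from the rest of the change, would compare with phenoxy at this carbon. A primary amine or a carboxylic acid at the same carbon is also untested in the compounds shown, so the range this position can span remains unknown.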